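The source may report more compounds than this note shows. Statements on the series, on what has been measured and on what is new or still open speak of the compounds shown alone.

Measured compounds:
Compound 1 `CCN(c1nc(C)cc(N2CCCCC2)n1)c1ccc(C(C)C)cc1Br`, 29 nM in an assay on isolated protein for binding affinity to corticotropin-releasing factor receptor 1 (Homo sapiens); a higher number here means a weaker inhibitor, a lower number a stronger inhibitor
Compound 2 `CCCN(CC1CC1)c1cc(C)nc(N(CC)c2ccc(C(C)C)cc2Br)n1`, 9 nM in this assay

Compound 2 holds the lowest of the two numbers shown in this assay; its nearest neighbour is compound 1, and the step of a 3.2-fold lower number from compound 1 to compound 2 (0.51 log units; beyond the scatter) puts it beyond the scatter. Among the measured compounds shown here, the single measured step therefore concerns the same position of the shared core that is varied next: an amino substituent on an aromatic carbon, with (cyclopropylmethyl)(propyl)amino in place of piperidin-1-yl.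

Compound 3 `CCC(CC)c1cc(C)nc(N(CC)c2ccc(C(C)C)cc2Br)n1` carries the change (pentan-3-yl in place of (cyclopropylmethyl)(propyl)amino on an aromatic carbon). For the measured compounds named here, no measured pair shows the exchange of an amino group for an all-carbon branch at this site, so the step of a 3.2-fold lower number from compound 1 to compound 2 (0.51 log units; beyond the scatter) bears on it only in showing that the position tolerates variation of the attached group with a modest shift in number. With the nitrogen and the three-membered ring both gone, a modest rise in number is expected rather than a drop, and the estimate for compound 3 follows as a 2.2-fold higher number from compound 2 to compound 3 (0.35 log units; beyond the scatter). Compound 3 is thus expected to give 20 nM in this assay, within a range of 7 nM to 60 nM.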

Compound 3, inhibition constant: 2 nM
Compound 3: the middle estimate sits 10-fold (1.00 log units) above what was measured; measured number outside the range, below it.
By their numbers in this assay, from the lowest: compound 3; then compound 2; then compound 1.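

In this assay, a nitrogen attached to the aromatic carbon proves unnecessary at this position: the all-carbon pentan-3-yl group, with no hydrogen-bond acceptor and no three-membered ring, gives a 4.5-fold lower number from compound 2 to compound 3 (0.65 log units; beyond the scatter). Measured against the piperidin-1-yl group, the same branch gives a 15-fold lower number from compound 1 to compound 3 (1.16 log units; beyond the scatter), a large step that exceeds the modest shift seen between the two amino groups, so among these three compounds the choice between an amino group and a carbon branch at this site matters at least as much as the choice of amino group. Nothing measured here accounts for the lower number carried by the carbon branch.

The compounds shown do not separate the effect of the attached atom from that of the branch's shape, which a diethylamino group, the nitrogen counterpart of pentan-3-yl, would do directly. They also leave open how much larger the carbon branch can become, as in heptan-4-yl, and whether a cyclopentyl ring or a methoxy group would serve at this position as well.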